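Cyano on compound 2: an expected step

A few compounds are considered here, and "the series" means these few. Any claim that something is new, unique, unknown or untested is made for them only; others in the source may bear on it.

Measured so far in a functional assay for inhibition, with Homo sapiens as the target; a lower number here means a stronger inhibitor, a higher number a weaker inhibitor
Compound 1 (`COc1ccc(O)c(CNc2ccc(F)cc2F)c1`) gives 1300 nM
Compound 2 (`Oc1cc2c(cc1CNc1ccccc1)OCCC2`) gives 1700 nM
Compound 3 (`OCc1ccccc1NCc1cc2c(cc1O)CCCO2`) gives 21000 nM

Compound 2, at 1700 nM, lies within the scatter of compound 1 and well under compound 3. Compound 4 (`N#Cc1ccc(NCc2cc3c(cc2O)CCCO3)cc1`) has not been measured. It carries cyano in place of hydrogen on an aromatic carbon of compound 2, para to a large group (cyano in place of hydrogen on an aromatic carbon).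

Among the compounds with values here, only one measured step bears on this change. Hydroxymethyl in place of hydrogen on an aromatic carbon gave a large rise in the number (a 12-fold higher number from compound 2 to compound 3 (1.09 log units; beyond the scatter)). That is a single example with a different group, so it supports the direction only weakly and does not set the size. Compound 1 differs from compound 2 in more than one place and offers no clean comparison. A modest move towards a higher number is therefore expected, well short of that large step.

In this assay the expected change is a 1.8-fold higher number from compound 2 to compound 4 (0.25 log units; within the scatter) (an estimate, with wide uncertainty). Compound 4 is expected at 3000 nM (estimated range 700 nM to 13000 nM).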

Compound 4, half-maximal inhibitory concentration in the Homo sapiens assay: 1600 nM
For compound 4 the middle estimate is 1.9-fold (0.27 log units) above the measured one; the measured number falls inside the stated range.
By their numbers in the Homo sapiens assay, from the lowest: compounds 1, 4 and 2 (each within the scatter of the next); then compound 3.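

In the Homo sapiens assay, cyano in place of hydrogen on an aromatic carbon, para to a large group, gives a 1.1-fold lower number from compound 2 to compound 4 (0.03 log units; within the scatter), with compound 2 at 1700 nM and compound 4 at 1600 nM, so this position tolerates cyano on this read-out. Within the data shown here, the only other change on this ring, hydroxymethyl, gave a 12-fold higher number from compound 2 to compound 3 (1.09 log units; beyond the scatter), so a substituent on this ring does not by itself cost activity, and the two groups part clearly in their effect. In a physicochemical assay for lipophilicity (on this read-out lower numbers stand for lower lipophilicity and higher numbers for higher lipophilicity), the cyano change gives a number 0.10 log units higher from compound 2 to compound 4 (within the scatter), with compound 2 at 3.5 and compound 4 at 3.6, so neither read-out separates compound 4 from compound 2.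

On these data alone, whether an amine or a carboxylic acid at the same aromatic carbon would also leave the number in place remains open, as does the behaviour of cyano elsewhere on this ring. Nothing measured here explains why cyano and hydroxymethyl part in this way.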